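The source may report more compounds than this note shows. Statements on the series, on what has been measured and on what is new or still open speak of the compounds shown alone.

Measured so far:
- Compound 1 `COc1ccc(Nc2cc(C)nc(SCc3nc4ccccc4[nH]3)n2)cc1`: in a functional assay on MCF7 cells (Homo sapiens) for cytotoxicity, read by MTT assay, with a stated time of 72 h (a lower number here means a stronger inhibitor, a higher number a weaker inhibitor), compound 1 gives 61100 nM.
- Compound 2 `Cc1ccc(Nc2cc(C)nc(SCc3nc4ccccc4[nH]3)n2)cc1`: in this assay compound 2 gives 56500 nM.
- Compound 3 `Cc1cc(N(C)Cc2ccccc2)nc(SCc2nc3ccccc3[nH]2)n1`: in this assay compound 3 reaches only a limit, > 100000 nM.

All three share the same core and differ only in the group attached to one aromatic carbon. Compound 1 and compound 2 are within the scatter of each other a 1.1-fold lower number from compound 1 to compound 2 (0.03 log units; within the scatter). Compound 3 sits at a limit of the assay (the limit of > 100000 nM in this assay, at which 1 of the 3 values shown sits).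

Compound 4 `Cc1cc(N2CCCCC2)nc(SCc2nc3ccccc3[nH]2)n1` is not yet measured. It differs from compound 1 in one place: piperidin-1-yl in place of (4-methoxyphenyl)amino on an aromatic carbon.

For the measured compounds named here, the steps that bear on this are the two in which an arylamino group gave way to benzyl(methyl)amino, a group that, like piperidin-1-yl, carries 0 hydrogen-bond donors: an at least 1.6-fold higher number from compound 1 to compound 3 (0.21 log units; that floor lies within the scatter) and an at least 1.7-fold higher number from compound 2 to compound 3 (0.24 log units; that floor lies within the scatter). From the compounds shown here alone, both point toward a weaker inhibitor, though each floor lies within the scatter, so the true size of the step is unknown. For compound 4 a step upward of similar or larger size is therefore expected, a 1.6-fold higher number from compound 1 to compound 4 (0.21 log units; within the scatter), with a real chance that only a limit is reported. Compound 4 is estimated at 100000 nM, within a range of 40000 nM to 250000 nM.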

Compound 4, half-maximal inhibitory concentration: > 100000 nM
Compound 4 gave a limit, no number; the forecaster's own chance of this, stated with the estimate: 55%; the middle value lies on the limit itself.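

In this assay compound 4 gives > 100000 nM, which is a limit and not a number. From the compounds shown here alone, putting piperidin-1-yl on this aromatic carbon gives an at least 1.6-fold higher number from compound 1 to compound 4 (0.21 log units; that floor lies within the scatter) and an at least 1.7-fold higher number from compound 2 to compound 4 (0.24 log units; that floor lies within the scatter), so these steps are floors and their true size is unknown. Until now only benzyl(methyl)amino had reached the limit here, but piperidin-1-yl, a smaller group with one six-membered non-aromatic ring, 0 hydrogen-bond donors and no aromatic ring, does the same, so among the compounds shown only the two arylamino groups give a readable number, and compound 3 and compound 4 end in the same place: the limit of > 100000 nM in this assay, at which 2 of the 4 values shown sit.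

The step from compound 3 to compound 4 cannot be read, so these two groups cannot be ranked against each other. Also open, going by these compounds, is whether the amine hydrogen or the aromatic ring of the arylamino groups matters more, a question that a cyclohexylamino group, which keeps that hydrogen on a non-aromatic ring, could help to separate.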